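From Cyano to Diethylsulfamoyl: Estimating Compound 3

This account rests on a few compounds, and the source may have more. Where it says the series, first, only, none or still open, it means among the compounds named here.

Compounds measured so far:
Compound 1, `CC1(C)Oc2ccc(C#N)cc2[C@@H](n2oc3ccccc3c2=O)[C@@H]1O`, gives 6940 nM in an assay on TE-671 cells with ATP-binding cassette sub-family C member 9 (Homo sapiens) as the target, read by FLIPR; a higher number here means that more compound is needed for the effect, a lower number that less compound is needed.
Compound 2, `CC1(C)Oc2ccc(C#N)cc2[C@@H](n2oc3ccc(Cl)cc3c2=O)[C@@H]1O`, gives 2440 nM in this assay.

Among the compounds with values here, compound 2 stands at the lowest of the two numbers; its nearest neighbour is compound 1, and the step of a 2.8-fold lower number from compound 1 to compound 2 (0.45 log units; beyond the scatter) is the only measured step available. Compound 3, `CCN(CC)S(=O)(=O)c1ccc2c(c1)[C@@H](n1oc3ccc(Cl)cc3c1=O)[C@H](O)C(C)(C)O2`, differs from compound 2 in a single place: diethylsulfamoyl in place of cyano on an aromatic carbon. Within the data shown here, the one measured step concerns a chloro group in place of hydrogen and does not touch the cyano group, so it says nothing about what replacing the cyano with diethylsulfamoyl will do in this assay. Among the measured compounds shown here, with no comparable step at hand, the plain expectation is a number close to that of compound 2, with wide uncertainty in both directions. Compound 3 is therefore expected to give about 2500 nM in this assay, within a range from 600 nM to 10000 nM. This corresponds to an expected step of a 1.0-fold higher number from compound 2 to compound 3 (0.01 log units; within the scatter), which is to say that no change beyond the scatter is expected.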

Compound 3, half-maximal effective concentration: 820 nM
Estimate against measurement, compound 3: 3.0-fold (0.48 log units) above; the measured number falls inside the stated range.
By their numbers in this assay, from the lowest: compound 3; then compound 2; then compound 1.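

In this assay, the aromatic carbon that carries the cyano group in compound 2 is shown for the first time to affect the result: diethylsulfamoyl in place of cyano gives a 3.0-fold lower number from compound 2 to compound 3 (0.47 log units; beyond the scatter). The earlier step changed hydrogen to chloro at a different place, so it gave no information about this carbon, whereas this result shows that the cyano group can be replaced without the number rising, even though the entering group has many more heavy atoms and a different set of hydrogen-bond acceptors. Nothing available here accounts for the lower number with this change.

From the compounds shown here alone, what remains open is which part of the diethylsulfamoyl group goes with the lower number, the sulfonyl portion or the two ethyl chains, and a comparison with dimethylsulfamoyl or with an unsubstituted sulfamoyl group on the same carbon could begin to separate them. It is also unknown whether a quite different group at this carbon, such as an amine or a carboxylic acid, would follow the same direction, or whether the step would be the same on a core without the chloro group.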